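A few compounds are considered here, and "the series" means these few. Any claim that something is new, unique, unknown or untested is made for them only; others in the source may bear on it.

Measured in a functional assay on A549 cells (Homo sapiens) for cytotoxicity, read by MTT assay, with a stated time of 72 h; a lower number here means a stronger inhibitor, a higher number a weaker inhibitor:
- compound 1 `COc1cc2ncnc(Nc3ccc(F)c(Cl)c3)c2cc1NC(=O)/C=C/c1ccc(F)cc1Cl`: "not active" (no number reported)
- compound 2 `COc1ccc(OC)c(/C=C/C(=O)Nc2cc3c(Nc4ccc(F)c(Cl)c4)ncnc3cc2OC)c1`: 11200 nM
- compound 3 `COc1cc2ncnc(Nc3ccc(F)c(Cl)c3)c2cc1NC(=O)/C=C/c1ccccc1[N+](=O)[O-]`: 33300 nM

Only two of these compounds have a number, and compound 3 holds the higher one, which marks the weaker inhibitor. The measured step is a 3.0-fold higher number from compound 2 to compound 3 (0.47 log units; beyond the scatter). It is modest but beyond the usual scatter, and it goes with 2-nitrophenyl in place of 2,5-dimethoxyphenyl. Compound 1 has no number and cannot be placed on this scale.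

Compound 4 `O=C(/C=C/c1ccccc1[N+](=O)[O-])Nc1cc2c(Nc3ccc(F)c(Cl)c3)ncnc2cc1O[C@H]1CCOC1` differs from compound 3 in one place: oxolan-3-yl in place of methyl on an oxygen on an aromatic ring. In words, this is oxolan-3-yl in place of methyl on an oxygen on an aromatic ring, or methoxy to (oxolan-3-yl)oxy.

Among the measured compounds shown here, no measured step changes this group. For the measured compounds named here, the one available step, a 3.0-fold higher number from compound 2 to compound 3 (0.47 log units; beyond the scatter), lies at another place in the structure, so it shows only how far a single change has moved the numbers here. With no evidence for a direction, no shift beyond the scatter is expected. The expected change is a 1.1-fold lower number from compound 3 to compound 4 (0.05 log units; within the scatter). Compound 1 gave "not active" (no number reported), so a result without a number also remains possible. Compound 4 is estimated at 30000 nM, with an expected range from 10000 nM to 90000 nM.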

Compound 4, half-maximal inhibitory concentration: 8820 nM
For compound 4 the middle estimate is 3.4-fold (0.53 log units) above the measured one; measured number below the stated range.
By their numbers in this assay, from the lowest: compounds 4 and 2 (each within the scatter of the next); then compound 3.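

Among the compounds shown here, this is the first measured change at the oxygen on the aromatic ring, and it shows that the group placed there can move the result in this assay. Replacing methyl with oxolan-3-yl gives a 3.8-fold lower number from compound 3 to compound 4 (0.58 log units; beyond the scatter) and so moves the number towards the stronger-inhibitor end of the scale, even though the entering group is larger, with 5 heavy atoms instead of 1, and brings a five-membered non-aromatic ring, a hydrogen-bond acceptor and a defined stereocentre. Nothing available explains the drop or shows which of these features matters.

On these data alone, this single step was measured with 2-nitrophenyl on the chain, so it remains open whether the same replacement would lower the number with 2,5-dimethoxyphenyl or with the substituted phenyl of compound 1 in that place. The compounds shown also do not tell how the mirror-image form of oxolan-3-yl, a simple ethyl group or a longer chain ending in an amine would behave on this oxygen.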